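A few compounds are considered here, and "the series" means these few. Any claim that something is new, unique, unknown or untested is made for them only; others in the source may bear on it.

Working notes on the series, read in an ADME assay on a cell-free system (plasma, Homo sapiens); on this read-out lower numbers stand for a smaller free fraction and higher numbers for a larger free fraction. Three compounds with a shared core have been taken to this measurement: compound 1 (`COCCN(C)S(=O)(=O)c1ccc(C)c(C#Cc2cc(Cl)ccc2OCC(=O)O)c1`), compound 2 (`CC(C)S(=O)(=O)c1ccc(Cl)c(C#Cc2cc(Cl)ccc2OCC(=O)O)c1`) and compound 3 (`CCCS(=O)(=O)c1ccc(F)c(C#Cc2cc(Cl)ccc2OCC(=O)O)c1`). In this assay compound 1 gives 0.006 and compound 3 gives 0.01, and these two numbers lie within the scatter of each other. Among the measured compounds shown here, for compound 2 the entry stands as "not determined" (no result reported), which leaves compound 3 as the only numerical neighbour of compound 1. For the measured compounds named here, no two measured compounds differ in one place only, so the series offers no measured step for any single change.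

Compound 4 (`Cc1ccc(S(=O)(=O)N(C)C(C)C)cc1C#Cc1cc(Cl)ccc1OCC(=O)O`) is the next to be read. Its difference from compound 1 is isopropyl in place of 2-methoxyethyl on a sulfonamide nitrogen. Going by the values given here, with no measured step for this change, the expectation rests on compound 1 at 0.006 and on compound 3 at 0.01, the only two numbers available. The expected step, a 1.2-fold lower number from compound 1 to compound 4 (0.08 log units; within the scatter), is estimated to stay within the scatter, with no firm direction. For compound 4 the estimated unbound fraction is 0.005, with an expected range of 0.0025 to 0.01.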

Compound 4, unbound fraction: 0.002
Beside the measured number, compound 4's estimate is 2.5-fold (0.40 log units) above it, outside the stated range (below it).
By their numbers in this assay, from the lowest: compound 4; then compounds 1 and 3 (each within the scatter of the next).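

In this assay, the exchange of 2-methoxyethyl for isopropyl on a sulfonamide nitrogen gives a 3.0-fold lower number from compound 1 to compound 4 (0.48 log units; beyond the scatter). Among the compounds shown here, this is the first single change measured, and it shows that the group on this nitrogen can shift the free fraction by more than the usual scatter, which the earlier numbers, lying within the scatter of each other, could not show. Of the counted features, 2-methoxyethyl carries 1 hydrogen-bond acceptor and isopropyl 0, but nothing measured here bears on why the number moves.

Open, from the compounds shown here alone, is how a 2-hydroxyethyl, a straight propyl chain or a 2-(dimethylamino)ethyl group on the same sulfonamide nitrogen would read, and so whether the step follows the oxygen of 2-methoxyethyl or the branched shape of isopropyl. Also open, going by these compounds, is whether the same exchange gives a step of this size when the methyl on the shared core is replaced by a chlorine or a fluorine, as the ring substituents of compounds 2 and 3 suggest.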